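Compound 2 to compound 4: bromo in place of chloro

The source may report more compounds than this note shows. Statements on the series, on what has been measured and on what is new or still open speak of the compounds shown alone.

Of the compounds shown here, three have numbers so far in a functional assay on HepG2 cells (Homo sapiens) for cytotoxicity, with a stated time of 24 h; a higher number here means a weaker inhibitor, a lower number a stronger inhibitor. Compound 1 (`COc1ccc(Cl)cc1C(=O)Nc1ccc(C(F)(F)F)cc1O`) gives 4910 nM. Compound 2 (`COc1cc(Cl)ccc1C(=S)Nc1ccc(Cl)cc1O`) gives 5110 nM. Compound 3 (`COc1cc(Cl)ccc1C(=S)Nc1cc(Cl)c(Cl)cc1O`) gives 3160 nM. Compound 2 stands within the scatter of both other compounds, so these numbers do not separate it from either one.

Compound 4 (`COc1cc(Cl)ccc1C(=S)Nc1ccc(Br)cc1O`) has not yet been measured. Its difference from compound 2 is bromo in place of chloro on an aromatic carbon, meta to a hydroxy group and para to a large group.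

Within the data shown here, one measured step bears on this change: chloro in place of hydrogen on an aromatic carbon, a 1.6-fold lower number from compound 2 to compound 3 (0.21 log units; within the scatter). That step stays within the scatter. Compound 1 differs from compound 2 in more than one place and offers no single-change comparison. Among the measured compounds shown here, no measured step exchanges chloro for bromo directly, so the evidence is indirect. For the measured compounds named here, with only that one small step as a guide, no shift beyond the scatter is expected in this assay. The expected step is a 1.1-fold lower number from compound 2 to compound 4 (0.06 log units; within the scatter), which would stay within the scatter. For compound 4 the estimated value is 4500 nM, with an expected range from 2500 nM to 8000 nM.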

Compound 4, half-maximal inhibitory concentration: 3880 nM
Beside the measured number, compound 4's estimate is 1.2-fold (0.06 log units) above it; the range from low to high includes it.
By their numbers in this assay, from the lowest: compounds 3, 4, 1 and 2 (each within the scatter of the next).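

In this assay, the step at this position, on an aromatic carbon meta to a hydroxy group and para to a large group, is a 1.3-fold lower number from compound 2 to compound 4 (0.12 log units; within the scatter). Unlike the earlier step, a 1.6-fold lower number from compound 2 to compound 3 (0.21 log units; within the scatter), which put chloro in place of hydrogen, this one exchanges one halogen for another at a single site, and it shows that chloro and bromo are not separated here in this cytotoxicity read-out, so the thioamide series keeps its number across this exchange. No measured property of these compounds bears on the result, so the data give no explanation for it.

Both single-change steps in the series stay within the scatter, so no change shown so far moves the number in this assay by more than repeated measurement would. From the compounds shown here alone, whether this position responds at all remains open, and a group of a different kind here, such as an amine or a carboxylic acid in place of the halogen, would test that more sharply than another exchange of one halogen for another.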